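The source may report more compounds than this note shows. Statements on the series, on what has been measured and on what is new or still open speak of the compounds shown alone.

Compound 1, `COc1cc(CC(C)C(=O)N2CCN(c3ccc(C(F)(F)F)cc3[C@@H](N)CC(C)C)CC2)ccc1Cl`, is the reference point of this pair. Among the compounds with values here, in an assay on HEK293 cells for displacement of a labelled ligand from Melanocortin receptor 4 (Homo sapiens) (a lower number here means a stronger inhibitor, a higher number a weaker inhibitor), compound 1 gives 230 nM, the lowest of the two numbers measured so far. Within the data shown here, its only measured neighbour is compound 2, `COc1ccc(OCC(=O)N2CCN(c3ccc(C(F)(F)F)cc3[C@@H](N)CC(C)C)CC2)cc1`, which in this assay gives 3800 nM; the step of a 17-fold higher number from compound 1 to compound 2 (1.22 log units; beyond the scatter) exchanges the whole chain on the carbonyl carbon at once, so it shows that this part of the molecule matters, but it does not separate the contribution of the aromatic substituents from that of the chain.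

The unmeasured compound 3, `COc1ccc(CC(C)C(=O)N2CCN(c3ccc(C(F)(F)F)cc3[C@@H](N)CC(C)C)CC2)cc1`, keeps the chain of compound 1 and alters only the aromatic ring on it: 4-methoxyphenyl in place of 4-chloro-3-methoxyphenyl on a saturated chain carbon, two bonds along the chain from a carbonyl carbon. Among the measured compounds shown here, no measured step isolates this exact exchange. For the measured compounds named here, the single relevant comparison, from compound 1 to compound 2, was large but confounded, so a weaker effect in the same direction seems the most reasonable expectation. Compound 3 is therefore expected at 500 nM, within a range of 150 nM to 1600 nM, which means an estimated step of a 2.2-fold higher number from compound 1 to compound 3 (0.34 log units; beyond the scatter).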

Compound 3, inhibition constant: 120 nM
Estimate against measurement, compound 3: 4.2-fold (0.62 log units) above; measured number below the stated range.
By their numbers in this assay, from the lowest: compounds 3 and 1 (each within the scatter of the next); then compound 2.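

Exchanging 4-chloro-3-methoxyphenyl for 4-methoxyphenyl on the saturated chain carbon, two bonds along the chain from a carbonyl carbon, gives a 1.9-fold lower number from compound 1 to compound 3 (0.28 log units; within the scatter) in this assay, so this ring change cannot be told apart from the ordinary spread of repeated measurements. With the 4-methoxyphenyl ring present on both sides, the comparison with 1-(4-methoxybenzyl)ethyl in place of (4-methoxyphenoxy)methyl on a carbonyl carbon gives a 32-fold lower number from compound 2 to compound 3 (1.50 log units; beyond the scatter), which ties the large difference among these compounds to the chain joining the ring to the carbonyl, and not to the ring substituents that the opening comparison could not separate from it. Nothing available here explains why either exchange has the size it has.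

The chain exchange alters two things at once, an oxygen atom replaced by carbon and an added methyl group, so the compounds shown do not reveal which of the two accounts for the large difference. Also open, going by these compounds, is how a simple 4-chlorophenyl ring or an unsubstituted phenyl ring would behave on the chain of compound 3.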